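The source may hold more compounds than are shown below. What is called first, only, known or untested is meant among the compounds shown, and "the series" means these compounds.

Three compounds from one series were tested for their ability to slow the growth of a human breast cancer cell line. In a functional assay on T47D cells (Homo sapiens) for inhibition, read by sulforhodamine B assay, with a stated time of 48 h (on this read-out higher numbers stand for weaker inhibition of growth and lower numbers for stronger inhibition of growth), compound 1 `COC(=O)[C@@]1(C)CCC=C2[C@@H]1CC[C@@H](C)[C@]2(C)Cc1c[nH]c2ccc(C)cc12` gives 20000 nM. Compound 2 `COC(=O)[C@@]1(C)CCC=C2[C@@H]1CC[C@@H](C)[C@]2(C)Cc1c(C)[nH]c2c(Cl)cccc12`, which carries a different pattern of small groups on its indole part, gives 27000 nM in this assay. Compound 3 `COC(=O)[C@@]1(C)CC[C@@H]2C3=C1CC[C@@H](C)[C@]3(C)C[C@@H]1c3cc(C)ccc3N[C@H]21`, whose ring system is more fully fused, gives 23000 nM in this assay. None of these three numbers can be separated from the others: the gap from compound 3 to compound 1 and the gap from compound 3 to compound 2 both lie within the scatter of repeated measurements, so all three are best read as equally weak inhibitors of growth.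

Compound 4 `COC(=O)[C@@]1(C)CC[C@@H]2C3=C1CC[C@@H](C)[C@]3(C)C[C@@H]1c3cc(F)ccc3N[C@H]21` has not yet been measured. It is compound 3 with one change: fluoro in place of methyl on an aromatic carbon. Within the data shown here, no matched pair among the measured compounds shows what this exchange does, so there is no measured step to lean on. The expectation is therefore modest: in this assay compound 4 is expected to give about 24000 nM, with a plausible range from 10000 nM to 60000 nM. The expected step of a 1.0-fold higher number from compound 3 to compound 4 (0.02 log units; within the scatter) is no larger than the scatter, in no particular direction.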

Compound 4, concentration for 50% growth inhibition: 27000 nM
For compound 4 the middle estimate is 1.1-fold (0.05 log units) below the measured one, within the range that was stated.
By their numbers in this assay, from the lowest: compounds 1, 3, 2 and 4 (each within the scatter of the next).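

In this assay, among these compounds, the exchange of methyl for fluoro gives the first pair that differs in one place only, and the step, a 1.2-fold higher number from compound 3 to compound 4 (0.07 log units; within the scatter), cannot be told apart from the ordinary spread of repeated measurements. At this aromatic carbon, meta to a fused ring and para to a fused ring, methyl and fluoro therefore cannot be distinguished by this growth read-out, and both compounds remain weak inhibitors of growth, like the others in the series. Nothing measured here offers an explanation for this result.

Among the compounds shown here, this single pair covers only two small groups at one position, so it remains open whether a larger or quite different group at the same carbon, such as an amine, a carboxylic acid or a longer chain, would move the number beyond the scatter. From the compounds shown here alone, it also remains open whether the same exchange of methyl for fluoro would give a similar result on the core of compound 1, where the ring system is less fully fused.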